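A few compounds are considered here, and "the series" means these few. Any claim that something is new, unique, unknown or untested is made for them only; others in the source may bear on it.

Measured in a toxicity assay on Vero cells (Chlorocebus sabaeus) for inhibition; on this read-out lower numbers stand for an effect already at smaller amounts and higher numbers for an effect only at larger amounts of compound:
- Compound 1 `COc1cccc(NC(=O)c2nnn(Cc3ccncc3)c2N)c1`: > 50100 nM (a limit)
- Compound 2 `COc1cccc(NC(=O)c2nnn(Cc3ccc([S+](C)[O-])cc3)c2N)c1`: > 50100 nM (a limit)
- Compound 3 `COc1cccc(NC(=O)c2nnn(C(CO)c3ccc(C(C)C)cc3)c2N)c1`: 12600 nM

Compound 2 gives no number, only (the limit of > 50100 nM in this assay, at which 2 of the 3 values shown sit). Compound 4 `COc1cccc(NC(=O)c2nnn(Cc3ccc(OC(F)(F)F)cc3)c2N)c1` shares its core with compound 2 and differs in one group: a group of 5 heavy atoms (1 carbon, 1 oxygen, 3 fluorine; no ring) in place of a group of 3 heavy atoms (1 carbon, 1 oxygen, 1 sulfur; no ring), on an aromatic carbon. Trifluoromethoxy enters on an aromatic carbon of a six-membered aromatic ring of carbon only, para to a large group.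

Among the compounds with values here, the one measured step, a step that the two limits leave unreadable from compound 1 to compound 2, offers no size to carry over. Within the data shown here, compound 3 gives 12600 nM, the only true number here, but it differs from compound 2 in more than one place. Since compound 3 reads 12600 nM a number is possible in this assay, so a modest move towards lower numbers is expected. Compound 4 may well stay at the limit, though. The expected change is an at least 1.2-fold lower number from compound 2 to compound 4 (0.09 log units; that floor lies within the scatter). For compound 4 the estimate is 40000 nM, with an expected range from 14000 nM to 100000 nM.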

Compound 4, half-maximal effective concentration: > 50100 nM
Compound 4: a limit, no number; the forecaster's own chance of this, stated with the estimate: 55%; middle value at least 1.2-fold (0.09 log units) from the limit.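

In this assay compound 4 gives > 50100 nM, a limit and not a number. Within the data shown here, compound 2 also sits at a limit, so no step between compound 2 and compound 4 can be read. The compounds shown leave open whether trifluoromethoxy changes the value at all, and which difference in compound 3 goes with its 12600 nM.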